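A few compounds are considered here, and "the series" means these few. Any claim that something is new, unique, unknown or untested is made for them only; others in the source may bear on it.

Measured so far in a functional assay (brain) for inhibition, with Rattus norvegicus as the target; on this read-out higher numbers stand for weaker inhibition and lower numbers for stronger inhibition:
compound 1 `CCNc1cccnc1N1CCN(CC2(C)CCc3c(C)c(O)c(C)c(C)c3O2)CC1`: 1000 nM
compound 2 `COc1ccccc1N1CCN(CC2(C)CCc3c(C)c(O)c(C)c(C)c3O2)CC1`: 1000 nM
compound 3 `Cc1c(C)c2c(c(C)c1O)CCC(C)(CN1CCN(c3ccccn3)CC1)O2`: 1000 nM

All three share one core and differ only in the group on the amine nitrogen of the six-membered non-aromatic ring with two nitrogens. On this read-out compound 3 stands level with compounds 1 and 2; none of the three is set apart from the others. The steps among them are no change at the digits printed from compound 1 to compound 2 (within the scatter), no change at the digits printed from compound 1 to compound 3 (within the scatter) and no change at the digits printed from compound 2 to compound 3 (within the scatter).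

Compound 4 `Cc1c(C)c2c(c(C)c1O)CCC(C)(CN1CCN(c3ncccn3)CC1)O2` is not yet measured. It differs from compound 3 as follows: pyrimidin-2-yl in place of pyridin-2-yl on an amine nitrogen in a ring. Among the measured compounds shown here, no measured pair covers this exact exchange. For the measured compounds named here, the steps that bear on it are those at the same ring nitrogen, no change at the digits printed from compound 1 to compound 2 (within the scatter) and no change at the digits printed from compound 2 to compound 3 (within the scatter), where exchanging one aromatic group for another on that nitrogen, including the removal of an ethylamino group, left this assay unchanged within the scatter. On that basis the step of no change at the digits printed from compound 3 to compound 4 (within the scatter) is expected to stay within the scatter as well, with no direction favoured. For compound 4 the estimate is 1000 nM, with a range from 500 nM to 2000 nM.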

Compound 4, half-maximal inhibitory concentration: 1000 nM
For compound 4 middle estimate and measured number coincide at the digits printed, and the stated range covers the measured number.
By their numbers in this assay, from the lowest: compounds 1, 2, 3 and 4 (each within the scatter of the next).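

In this assay, pyrimidin-2-yl in place of pyridin-2-yl on the amine nitrogen in the ring gives no change at the digits printed from compound 3 to compound 4 (within the scatter), and this is the first exchange shown that takes the six-membered aromatic ring from 1 to 2 hetero atoms and from 1 to 2 hydrogen-bond acceptors at the same 6 heavy atoms. The comparisons with the other two aromatic groups at this position read no change at the digits printed from compound 2 to compound 4 (within the scatter) and no change at the digits printed from compound 1 to compound 4 (within the scatter), so pyrimidin-2-yl is not set apart from 2-methoxyphenyl or 3-(ethylamino)pyridin-2-yl on this read-out, and all four compounds now form one group with no step beyond the scatter. No evidence is available that bears on this result.

Going by these compounds, all four compounds carry a six-membered aromatic ring on this nitrogen, so it remains open how this assay would respond to a non-aromatic group there, such as a cyclohexyl ring, an acyl group or a longer alkyl chain. The shared core is also constant throughout, which leaves open whether a methyl ether in place of its hydroxyl, or a longer chain leading to the ring nitrogen, would separate the values.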